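A Methyl on the Furan of a Hydroxamic Acid

The source may hold more compounds than are shown below. What is called first, only, known or untested is meant among the compounds shown, and "the series" means these compounds.

Of the compounds shown here, three have so far been measured in a functional assay on MCF7 cells (Homo sapiens) for inhibition, read by MTT assay; a lower number here means a stronger inhibitor, a higher number a weaker inhibitor. Compound 1, with the structure `O=C(CCCCCCC(=O)Nc1nnc(-c2ccco2)s1)NO`, gives 880 nM in this assay, the highest number among the three. Compound 2, `COc1ccc(/C=C/C(=O)c2ccc(OCC(=O)NO)cc2)cc1`, gives 620 nM in this assay, a value that lies within the usual scatter of that of compound 1, so the two cannot be ranked against each other. Compound 3, `COc1ccc(-c2ocnc2-c2cc(Br)c(OC)c(OC)c2)cc1OCCCC(=O)NO`, gives 18 nM in this assay, a number far lower than that of compound 1, and this gap lies well beyond the scatter.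

Compound 4, `Cc1ccc(-c2nnc(NC(=O)CCCCCCC(=O)NO)s2)o1`, has not yet been measured. It differs from compound 1 in one place only: methyl in place of hydrogen on an aromatic carbon. Cut one bond further out, the change reads furan-2-yl to 5-methylfuran-2-yl, with the rest of the molecule left unchanged.

Going by the values given here, no pair of measured compounds differs in a single place, so there is no directly comparable step to lean on. Given the small size of the change, the step from compound 1 to compound 4 is expected to be modest and not clearly beyond the scatter in either direction, which is what a 1.3-fold lower number from compound 1 to compound 4 (0.10 log units; within the scatter) expresses. Compound 4 is therefore estimated to give about 700 nM in this assay, expected to fall between 300 nM and 1800 nM.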

Compound 4, half-maximal inhibitory concentration: 880 nM
Beside the measured number, compound 4's estimate is 1.3-fold (0.10 log units) below it, within the range that was stated.
By their numbers in this assay, from the lowest: compound 3; then compounds 2, 1 and 4 (each within the scatter of the next).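

Going by these compounds alone, the step from hydrogen to methyl on this aromatic carbon of the five-membered aromatic ring with 1 oxygen gives the first single-place comparison in this assay, and it reads no change at the digits printed from compound 1 to compound 4 (within the scatter). The earlier compounds shown here, none of which differed from another in a single place, could not show how any one position bears on the number; this pair shows that, at this carbon next to the ring oxygen, the furan-2-yl to 5-methylfuran-2-yl change of one heavy atom leaves the read-out without a step that can be told from the scatter. Nothing in the data available here bears on why the number stays the same, and the result stands only as an observation.

The compounds shown leave open whether this carbon would carry something other than methyl with the same outcome, such as an ethyl, a methoxy, an amine, a carboxylic acid or a phenyl ring. They also leave open what a longer chain or a shorter chain in place of the chain of compound 1 would do in this assay, with the furan-2-yl group kept as it is.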